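Adding a Second Fluorine to a Weak Sulfoxide Analogue

A few compounds are considered here, and "the series" means these few. Any claim that something is new, unique, unknown or untested is made for them only; others in the source may bear on it.

compound 1: `O=C(c1ccccc1)N1CCC(NCCSC(c2ccc(F)cc2)c2ccc(F)cc2)CC1` — 2.03 nM
compound 2: `O=C(c1ccc(F)cc1)N1CCC(NCCSC(c2ccc(F)cc2)c2ccc(F)cc2)CC1` — 32.1 nM
compound 3: `O=C(c1ccccc1F)N1CCC(NCC[S+]([O-])C(c2ccc(F)cc2)c2ccc(F)cc2)CC1` — 1310 nM

Of the compounds shown here, three have been measured in an assay on membranes from Cortex for displacement of a labelled ligand from Sigma non-opioid intracellular receptor 1 (Cavia porcellus), read by scintillation counting, with a stated time of 120 min; on this read-out lower numbers stand for stronger inhibition and higher numbers for weaker inhibition. Compound 1 gives 2.03 nM, compound 2 gives 32.1 nM, and compound 3 gives 1310 nM, the highest of the three numbers. Compound 1 and compound 2 differ in one place, (fluoro in place of hydrogen on an aromatic carbon), and this change gave a 16-fold higher number from compound 1 to compound 2 (1.20 log units; beyond the scatter). Compound 3 shares its overall layout with compound 1, but the difference between the two cores is not broken down here; its number stands far above those of compound 1 and compound 2.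

Compound 4, `O=C(c1ccc(F)cc1F)N1CCC(NCC[S+]([O-])C(c2ccc(F)cc2)c2ccc(F)cc2)CC1`, has not yet been measured. It is compound 3 with fluoro in place of hydrogen on an aromatic carbon. For the measured compounds named here, this is the same kind of change as the one from compound 1 to compound 2, not the same: in compound 4 the entering fluoro is meta to a fluoro group, whereas in compound 2 it is not. The step from compound 3 to compound 4 in this assay is therefore expected to be a 3.8-fold higher number from compound 3 to compound 4 (0.58 log units; beyond the scatter), resting on a 16-fold higher number from compound 1 to compound 2 (1.20 log units; beyond the scatter) while allowing that the core of compound 3 is a different one and that the matching step there may not carry over in full. Compound 4 is accordingly expected to give 5000 nM, estimated to lie between 1500 nM and 20000 nM.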

Compound 4, inhibition constant: 171 nM
Estimate against measurement, compound 4: 29-fold (1.47 log units) above, outside the stated range (below it).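

In this assay, fluoro in place of hydrogen on an aromatic carbon gave a 7.7-fold lower number from compound 3 to compound 4 (0.88 log units; beyond the scatter), whereas the same kind of change had given a 16-fold higher number from compound 1 to compound 2 (1.20 log units; beyond the scatter). The effect of this change therefore did not carry from one core to the other in either size or direction: the same change on two cores in this assay, a 16-fold higher number (1.20 log units; beyond the scatter) from compound 1 to compound 2 and a 7.7-fold lower number (0.88 log units; beyond the scatter) from compound 3 to compound 4, 120-fold (2.08 log units) apart, beyond the scatter of two such steps

What this does not show is which difference between the two pairs matters: the cores differ, and the entering fluoro is meta to a fluoro group in compound 4 but not in compound 2, while a single comparison of two steps gives no rule for any other core in the series.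

The compounds shown leave open how the 2-fluorophenyl and 2,4-difluorophenyl groups would behave on the core of compound 1, a comparison that could separate the part played by the core from that of the fluoro group already present in compound 3. They also leave open whether a chloro or a methoxy group in the place of the entering fluoro would move the number in the same direction on each core.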